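From Fluoro to Hydroxymethyl on a Saturated Ring Carbon

The source may report more compounds than this note shows. Statements on the series, on what has been measured and on what is new or still open speak of the compounds shown alone.

Among the compounds with values here, in an ADME assay on microsomes from liver (Mus musculus) for metabolic stability, with a stated time of 10 min (on this read-out lower numbers stand for a less stable compound and higher numbers for a more stable compound), compound 3 (`O=C(N1CC[C@](c2ccc(C(F)(C(F)(F)F)C(F)(F)F)cc2)(S(=O)(=O)c2ccc(F)cc2)C1)C1(F)CCS(=O)(=O)CC1`) gives 90% as the only number in this small set. Compound 1 (`CC[C@]1(C(=O)O)CC[C@H](C(=O)N2CC[C@](c3ccc(C(F)(C(F)(F)F)C(F)(F)F)cc3)(S(=O)(=O)c3ccc(F)cc3)C2)CC1`) stands at "not determined" (no result reported) and compound 2 (`COC(=O)[C@H]1CC[C@H](C(=O)N2CC[C@](c3ccc(C(F)(C(F)(F)F)C(F)(F)F)cc3)(S(=O)(=O)c3ccc(F)cc3)C2)CC1`) at "not determined" (no result reported) in the same read-out, so neither offers a comparison. Compound 4 (`O=C(N1CC[C@](c2ccc(C(F)(C(F)(F)F)C(F)(F)F)cc2)(S(=O)(=O)c2ccc(F)cc2)C1)C1(CO)CCS(=O)(=O)CC1`) carries one change from compound 3 (hydroxymethyl in place of fluoro on a saturated ring carbon), with hydroxymethyl in place of fluoro on a saturated ring carbon. Within the data shown here, no measured pair shows what such a change does in this assay and compound 3 at 90% is the sole anchor, so a modest fall, about the size of the usual scatter, is expected. The estimated step (a number 10 percentage points lower from compound 3 to compound 4 (within the scatter)) points downward. For compound 4 the expected value is 80% with a range from 60% to 95% on this estimate.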

Compound 4, percent of the compound remaining: 31%
Compound 4: the middle estimate sits 49 percentage points above what was measured; measured number outside the range, below it.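

In this assay, placing hydroxymethyl where fluoro stood on this saturated ring carbon gives a number 59 percentage points lower from compound 3 to compound 4 (beyond the scatter), so the position is sensitive to a single change of substituent while the rest of the molecule stays the same. No measurement shown accounts for this fall. The compounds shown leave open whether the fall follows from the hydroxyl oxygen or from the added carbon, which methyl or methoxymethyl at this position could separate. From the compounds shown here alone, how an amine or a longer chain such as hydroxyethyl would fare here also remains open.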